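A few compounds are considered here, and "the series" means these few. Any claim that something is new, unique, unknown or untested is made for them only; others in the source may bear on it.

Measured in a functional assay on M21 cells (Homo sapiens) for antiproliferative activity, read by sulforhodamine B assay, with a stated time of 48 h; a lower number here means a stronger inhibitor, a higher number a weaker inhibitor:
- compound 1 `CN1CCN(c2ccc(S(=O)(=O)Oc3c(Cl)cc(Cl)cc3Cl)cc2)C1=O`: 1700 nM
- compound 2 `CN1CCN(c2ccc(S(=O)(=O)Oc3cccc(F)c3)cc2)C1=O`: 5800 nM
- compound 3 `CCN1CCN(c2ccc(S(=O)(=O)Oc3cccc(F)c3)cc2)C1=O`: 11000 nM

In this assay, compound 3 gives 11000 nM. Compound 2 gives 5800 nM. The gap between compound 2 and compound 3 lies within the scatter. Compound 1 gives 1700 nM. The gap between compound 1 and compound 3 lies beyond the scatter.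

The next compound to be measured is compound 4 `CCN1CCN(c2ccc(S(=O)(=O)Oc3ccc(OC)cc3)cc2)C1=O`, which has 4-methoxyphenyl in place of 3-fluorophenyl on an oxygen whose other neighbour is the sulfonyl sulfur: 4-methoxyphenyl in place of 3-fluorophenyl on an oxygen.

Among the compounds with values here, only one measured step is available, a 1.9-fold higher number from compound 2 to compound 3 (0.28 log units; within the scatter). It changes a different place in the structure and gives no direct size for this exchange. Within the data shown here, no measured step covers this exchange, so the data favour no direction, and no step beyond the scatter is expected in this assay. The expected step is a 1.2-fold lower number from compound 3 to compound 4 (0.09 log units; within the scatter). The estimated value for compound 4 is 9000 nM. The expected range for compound 4 is 3000 nM to 25000 nM.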

Compound 4, half-maximal inhibitory concentration: 26000 nM
Compound 4: middle estimate off by 2.9-fold (0.46 log units), on the low side; measured number outside the range, above it.
By their numbers in this assay, from the lowest: compound 1; then compounds 2 and 3 (each within the scatter of the next); then compound 4.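

In this assay, within the data shown here, the exchange of 3-fluorophenyl for 4-methoxyphenyl on the oxygen bound to the sulfonyl sulfur gives a 2.4-fold higher number from compound 3 to compound 4 (0.37 log units; beyond the scatter) and is the first measured change at this position. The number therefore responds to the group on this oxygen, though the step is modest, whereas the chain change giving a 1.9-fold higher number from compound 2 to compound 3 (0.28 log units; within the scatter) stays within the scatter. No measurement shown here speaks to the origin of this step.

The exchange alters both the substituent and its place on the phenyl ring, and the compounds shown do not separate these two changes. From the compounds shown here alone, how a nitrile, an amine or a carboxylic acid on the phenyl ring would compare on this same core also remains open.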